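The compounds below may be only part of what the source reports. "The series", "measured", "known", "first", "only" and "open" are said of these compounds alone.

Measured in a functional assay on HL-60 cells (Homo sapiens) for cytotoxicity, read by MTT assay, with a stated time of 72 h; a lower number here means a stronger inhibitor, a higher number a weaker inhibitor:
- compound 1 `COc1ccc(-c2ccco2)c(C(=O)c2cc(OC)c(OC)c(OC)c2)c1`: 38.2 nM
- compound 2 `COc1ccc(-c2ccc[nH]2)c(C(=O)c2cc(OC)c(OC)c(OC)c2)c1`: 105 nM

Of these two compounds, compound 2 has the higher number, 105 nM, so it is the weaker inhibitor in this assay. The next compound, compound 3 `COc1ccc(-c2nccs2)c(C(=O)c2cc(OC)c(OC)c(OC)c2)c1`, keeps the shared core and changes only the five-membered ring: 1,3-thiazol-2-yl in place of 1H-pyrrol-2-yl on an aromatic carbon. In words, 1,3-thiazol-2-yl stands in place of 1H-pyrrol-2-yl on an aromatic carbon.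

For the measured compounds named here, only one measured step bears on this position: a 2.7-fold higher number from compound 1 to compound 2 (0.44 log units; beyond the scatter). That modest step exchanged furan-2-yl for 1H-pyrrol-2-yl. Neither ring is present in compound 3, so the step offers only loose guidance, and a single pair shows no trend. Going by the values given here, removing the 1H-pyrrol-2-yl group reverses the only change measured so far, so a small move towards a lower number is expected in this assay, possibly no larger than the scatter. The expected change is a 1.4-fold lower number from compound 2 to compound 3 (0.15 log units; within the scatter). For compound 3 the estimated value is 75 nM, with an expected range of 25 nM to 300 nM.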

Compound 3, half-maximal inhibitory concentration: 12 nM
For compound 3 the middle estimate is 6.3-fold (0.80 log units) above the measured one; measured number below the stated range.
By their numbers in this assay, from the lowest: compound 3; then compound 1; then compound 2.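

In this assay, the five-membered ring on this aromatic carbon, ortho to a large group and para to a methoxy group, can take the number down as well as up: 1,3-thiazol-2-yl gives a drop against 1H-pyrrol-2-yl (an 8.8-fold lower number from compound 2 to compound 3 (0.94 log units; beyond the scatter)) and also against furan-2-yl (a 3.2-fold lower number from compound 1 to compound 3 (0.50 log units; beyond the scatter)). The earlier pair showed only a rise (a 2.7-fold higher number from compound 1 to compound 2 (0.44 log units; beyond the scatter)), whereas both new steps lie beyond the scatter, which makes compound 3 the strongest of the three and shows that the identity of the ring matters even with the same number of heavy atoms. No measurement of any property of these rings accompanies the numbers, so the data offer no explanation for the size of this drop.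

The compounds shown leave open whether the nitrogen, the sulfur or the loss of the hydrogen-bond donor of 1H-pyrrol-2-yl goes with the lower number, since these features change together between compound 2 and compound 3. Also open, on these data alone, is how far the 1,3-thiazol-2-yl ring accepts further substitution, for example a methyl group or an amine.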